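A few compounds are considered here, and "the series" means these few. Any claim that something is new, unique, unknown or untested is made for them only; others in the source may bear on it.

Measured so far in a functional assay on A549 cells (Homo sapiens) for antiproliferative activity, read by sulforhodamine B assay, with a stated time of 48 h; a higher number here means a weaker inhibitor, a lower number a stronger inhibitor:
Compound 1 `COc1cc(OC)c(/C=C/C(=O)C(=Cc2ccc(O)c(F)c2)C(=O)/C=C/c2c(OC)cc(OC)cc2OC)c(OC)c1`: 1060 nM
Compound 2 `COc1cc(OC)c(/C=C/C(=O)C(=Cc2cc(Br)c(O)c(OC)c2)C(=O)/C=C/c2c(OC)cc(OC)cc2OC)c(OC)c1`: 730 nM

Going by the values given here, only these two compounds have been measured in this assay, and compound 2 has compound 1 as its sole neighbour. The step between them, a 1.5-fold lower number from compound 1 to compound 2 (0.16 log units; within the scatter), does not separate them, so neither can be ranked above the other.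

The next compound, compound 3 `COc1cc(OC)c(/C=C/C(=O)C(=Cc2cc(OC)c(O)c(OC)c2)C(=O)/C=C/c2c(OC)cc(OC)cc2OC)c(OC)c1`, differs from compound 2 at one place: methoxy in place of bromo on an aromatic carbon. It has methoxy in place of bromo on an aromatic carbon, which turns 3-bromo-4-hydroxy-5-methoxyphenyl into 4-hydroxy-3,5-dimethoxyphenyl.

Among the compounds with values here, no measured step makes this exact exchange. The nearest evidence is the change of this same aryl group from 3-fluoro-4-hydroxyphenyl to 3-bromo-4-hydroxy-5-methoxyphenyl, a 1.5-fold lower number from compound 1 to compound 2 (0.16 log units; within the scatter). That single step is thin support, but it gives no reason to expect a large move, so no shift beyond the scatter is expected in this assay, in either direction. The expected change is a 1.1-fold higher number from compound 2 to compound 3 (0.04 log units; within the scatter). For compound 3 the estimated value is 800 nM, with an expected range from 350 nM to 1900 nM.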

Compound 3, half-maximal inhibitory concentration: 340 nM
Beside the measured number, compound 3's estimate is 2.4-fold (0.37 log units) above it; the measured number lies below the stated range.
By their numbers in this assay, from the lowest: compound 3; then compounds 2 and 1 (each within the scatter of the next).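

In this assay, methoxy in place of bromo on the aromatic carbon ortho to a hydroxy group gives a modest step beyond the scatter, a 2.1-fold lower number from compound 2 to compound 3 (0.33 log units; beyond the scatter), so this position responds to the exchange, which the step between the two earlier compounds could not show. The whole change of the aryl group, 4-hydroxy-3,5-dimethoxyphenyl in place of 3-fluoro-4-hydroxyphenyl, is also modest and beyond the scatter, a 3.1-fold lower number from compound 1 to compound 3 (0.49 log units; beyond the scatter), which places compound 3 lowest of the three, while compounds 1 and 2 remain unseparated. Nothing available explains why the methoxy compound gives the lower number.

On these data alone, only bromo and methoxy are compared directly at this position, so it remains open how an ethoxy group, a chloro group or an amine there would read. The methoxy-for-bromo exchange also rests on a single pair on the shared core, which leaves open whether the same step would appear on another aryl group.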